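Cutting the chain of compound 2 back

The source may report more compounds than this note shows. Statements on the series, on what has been measured and on what is new or still open speak of the compounds shown alone.

Among the measured compounds shown here, in a functional assay on MCF7 cells (Homo sapiens) for antiproliferative activity, read by MTT assay, with a stated time of 72 h (on this read-out lower numbers stand for stronger inhibition and higher numbers for weaker inhibition), compound 2 `CCCCCCCCCCCCCCNC[C@@H]1OC[C@H](N)[C@H]1O` gives 8830 nM, the only actual number available so far in this small set. Compound 1 `CCCCCCCNC[C@@H]1OC[C@H](N)[C@@H]1O` is recorded only as a limit, > 128000 nM, and so offers no exact figure for comparison.

The next compound to be tested is compound 3 `CCCCCCCCNC[C@@H]1OC[C@H](N)[C@H]1O`. It departs from compound 2 by hydrogen in place of hexyl on a saturated chain carbon, eight bonds along the chain from an amine nitrogen. In effect, the long chain of compound 2 is much reduced, while the rest of the structure stays the same.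

For the measured compounds named here, no measured pair shows what a change of this kind does, so any forecast rests on thin ground. The expectation of a loss in this assay leans on compound 1, which stands at the limit of > 128000 nM. Compound 3 might likewise return only a limit. The estimated step, a 6.8-fold higher number from compound 2 to compound 3 (0.83 log units; beyond the scatter), is toward weaker inhibition and beyond the scatter of repeated measurements. For compound 3 the expected value is 60000 nM, with an estimated range of 25000 nM to 128000 nM.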

Compound 3, half-maximal inhibitory concentration: > 128000 nM
Compound 3 was reported as a limit; the forecaster's own chance of this, stated with the estimate: 45%; at least 2.1-fold (0.32 log units) between middle value and limit.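

In this assay, replacing hexyl with hydrogen on a saturated chain carbon, eight bonds along the chain from an amine nitrogen, now has a measured effect: an at least 14-fold higher number from compound 2 to compound 3 (1.16 log units; beyond the scatter). Among the compounds shown here, with the rest of the structure unchanged, the measurable inhibition of compound 2 is lost when the chain is cut back, which the earlier compounds could not show, as neither had a partner differing from it in one place. Compound 3 is recorded only as a limit, so the step gives a lower bound on the effect of this change and not its full size: the limit of > 128000 nM in this assay, at which 2 of the 3 values shown sit.

The compounds shown leave open where between these two chain lengths measurable inhibition first appears, which a decyl or dodecyl chain on the same core would help to locate, and whether a chain longer than that of compound 2 would give a lower number. They also leave open whether the chain must be a plain alkyl one, or whether one ending in a hydroxyl group or an amine would serve as well.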